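The source may report more compounds than this note shows. Statements on the series, on what has been measured and on what is new or still open speak of the compounds shown alone.

Measured in an assay on isolated protein for inhibition of Amine oxidase [flavin-containing] B (Homo sapiens), read by fluorescence, with a stated time of 15 min; a lower number here means a stronger inhibitor, a higher number a weaker inhibitor:

compound 1, `O=C1OCc2cc(OCc3ccc(Cl)cc3)ccc21`, 13.9 nM
compound 2, `O=C1OCc2cc(OCc3ccc(F)cc3)ccc21`, 8.35 nM
compound 3, `CC(=O)c1ccc(OCc2cccc(F)c2)cc1F`, 96.5 nM

Compound 1 and compound 2 share one core; compound 3 has another, and the difference between the two cores is not broken down here. Within the shared core, one change is measured: chloro in place of fluoro on an aromatic carbon It gives a 1.7-fold higher number from compound 2 to compound 1 (0.22 log units; within the scatter). Compound 3 has the highest of the three numbers, and its gap to each of the others is beyond the scatter.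

Compound 4, `CC(=O)c1ccc(OCc2cccc(Cl)c2)cc1F`, is not yet measured. Among the compounds with values here, it differs from compound 3 thus: chloro in place of fluoro on an aromatic carbon This is the same kind of change as the one from compound 2 to compound 1, but not the same: in the measured pair the place is para to a large group, whereas in compound 3 and compound 4 it is meta to a large group. The step from compound 3 to compound 4 is expected to be a 1.5-fold higher number from compound 3 to compound 4 (0.16 log units; within the scatter), resting on the measured 1.7-fold higher number from compound 2 to compound 1 (0.22 log units; within the scatter), with added uncertainty for the different place and core. Compound 4 is therefore estimated at 140 nM, expected to lie between 60 nM and 350 nM.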

Compound 4, half-maximal inhibitory concentration: 13.3 nM
The estimate for compound 4 lay 11-fold (1.02 log units) above the measured number, outside the stated range (below it).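

In this assay, chloro in place of fluoro on an aromatic carbon, meta to a large group, gives a 7.3-fold lower number from compound 3 to compound 4 (0.86 log units; beyond the scatter) and so brings the second core to a number far lower than that of compound 3. Set beside the earlier step, the result shows that the size of this change did not carry over from one core to the other in this series: the same change on two cores in this assay, a 1.7-fold higher number (0.22 log units; within the scatter) from compound 2 to compound 1 and a 7.3-fold lower number (0.86 log units; beyond the scatter) from compound 3 to compound 4, 12-fold (1.08 log units) apart, beyond the scatter of two such steps. It does not show what separates the two steps, for the two pairs differ in core and in the place of the change at once, and two pairs alone set no rule for the series.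

On these data alone, only fluoro and chloro appear at the changed places, so it remains open how a bromo, a methyl or a methoxy group would read there. Also open, as far as these compounds go, is how the same change would read on each core at the place it occupies on the other.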